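Aryl variation on the chain carbon: compound 4

A few compounds are considered here, and "the series" means these few. Any claim that something is new, unique, unknown or untested is made for them only; others in the source may bear on it.

Compound 3 `Cc1ccc(C)c(/C=C(/SCc2ccc(F)cc2)C(=O)c2ccc(Br)cc2)c1` holds the lowest number of the three measured in a functional assay on DU-145 cells (Homo sapiens) for inhibition, read by trypan blue exclusion, with a stated time of 96 h (on this read-out higher numbers stand for weaker inhibition of growth and lower numbers for stronger inhibition of growth), giving 1000 nM. Compound 2 `Cc1cc(F)ccc1/C=C(/SCc1ccc(F)cc1)C(=O)c1ccc(Br)cc1` gives 10000 nM, and compound 1 `Cc1ccsc1/C=C(/SCc1ccc(F)cc1)C(=O)c1ccc(Br)cc1` gives 50000 nM. The steps of a 50-fold lower number from compound 1 to compound 3 (1.70 log units; beyond the scatter) and a 10-fold lower number from compound 2 to compound 3 (1.00 log units; beyond the scatter) show that the group on the double-bonded chain carbon bound to a double-bonded chain carbon governs the read-out strongly, while a 5.0-fold lower number from compound 1 to compound 2 (0.70 log units; beyond the scatter) is smaller. Compound 4 `Cc1cc(C)cc(/C=C(/SCc2ccc(F)cc2)C(=O)c2ccc(Br)cc2)c1` differs from compound 3 only in that group: 3,5-dimethylphenyl in place of 2,5-dimethylphenyl on a double-bonded chain carbon bound to a double-bonded chain carbon. Going by the values given here, no measured step exchanges one dimethylphenyl for another, so none bears directly on this change; the measured steps only show that the series is sensitive to this group. A step of uncertain direction, leaning toward a higher number, is expected: a 2.5-fold higher number from compound 3 to compound 4 (0.40 log units; beyond the scatter). Compound 4 is estimated at 2500 nM, within 500 nM to 12000 nM.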

Compound 4, concentration for 50% growth inhibition: 10000 nM
Estimate against measurement, compound 4: 4.0-fold (0.60 log units) below, within the range that was stated.
By their numbers in this assay, from the lowest: compound 3; then compounds 2 and 4 (each within the scatter of the next); then compound 1.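

With the atoms unchanged, 3,5-dimethylphenyl in place of 2,5-dimethylphenyl already separates the two compounds in this assay (a 10-fold higher number from compound 3 to compound 4 (1.00 log units; beyond the scatter)). The 3,5-dimethylphenyl group matches 4-fluoro-2-methylphenyl (no change at the digits printed from compound 2 to compound 4 (within the scatter)) yet still gives a lower number than 3-methylthiophen-2-yl (a 5.0-fold lower number from compound 1 to compound 4 (0.70 log units; beyond the scatter)), so among these four groups only 2,5-dimethylphenyl stands apart at the low end. No supporting data are available to explain the gap between the two dimethylphenyl groups. Open, on these data alone, is whether a methoxy group or a chlorine on this phenyl ring would keep the number of compound 3, and whether an amine would be tolerated at this position.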